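This account rests on a few compounds, and the source may have more. Where it says the series, first, only, none or still open, it means among the compounds named here.

Measured so far:
compound 1 `O=C(COc1ccc2c(=O)ccoc2c1)Nc1cccc(NC(=O)c2ccc([N+](=O)[O-])cc2)c1` gives 15 nM
compound 2 `Cc1cc(C(=O)Nc2cccc(NC(=O)COc3ccc4c(=O)ccoc4c3)c2)ccc1C(F)(F)F` gives 43 nM

In an assay on isolated protein for inhibition of Rho-associated protein kinase 2 (Homo sapiens), read by scintillation counting, radiometric assay and 33P incorporation, with a stated time of 40 min, in the presence of a further agent that is not named here (on this read-out higher numbers stand for weaker inhibition and lower numbers for stronger inhibition), compound 2 stands highest of the two numbers, with compound 1 nearest at a 2.9-fold higher number from compound 1 to compound 2 (0.46 log units; beyond the scatter). Compound 3 `Nc1cccc(C(=O)Nc2cccc(NC(=O)COc3ccc4c(=O)ccoc4c3)c2)c1` is not yet measured; it differs from compound 2 by a group of 7 heavy atoms (6 carbon, 1 nitrogen; one six-membered aromatic ring of carbon only) in place of a group of 11 heavy atoms (8 carbon, 3 fluorine; one six-membered aromatic ring of carbon only), on a carbonyl carbon. Going by the values given here, the only measured step, from compound 1 to compound 2, was a 2.9-fold higher number from compound 1 to compound 2 (0.46 log units; beyond the scatter) and changed the same ring on the same carbonyl carbon, so a modest step in either direction is plausible; the direction is not settled by these two compounds. Compound 3 is therefore expected at 25 nM, with a range of 8 nM to 80 nM, an estimated step of a 1.7-fold lower number from compound 2 to compound 3 (0.24 log units; within the scatter).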

Compound 3, half-maximal inhibitory concentration: 58 nM
Estimate against measurement, compound 3: 2.3-fold (0.37 log units) below; low and high end bracket the measured number.
By their numbers in this assay, from the lowest: compound 1; then compounds 2 and 3 (each within the scatter of the next).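

In this assay, 3-aminophenyl in place of the group in compound 2 gives a 1.3-fold higher number from compound 2 to compound 3 (0.13 log units; within the scatter), so the two cannot be told apart, although only 3-aminophenyl counts a hydrogen-bond donor and acceptor. Replacing 4-nitrophenyl with 3-aminophenyl gives a 3.9-fold higher number from compound 1 to compound 3 (0.59 log units; beyond the scatter), a modest step beyond the scatter. Nothing here explains why the numbers fall this way. The compounds shown leave open whether the amine itself matters, as compound 3 has no unsubstituted phenyl counterpart here. From the compounds shown here alone, how a carboxylic acid on this ring would read also stays open.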